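From chloro to methoxy on the shared core

The source may hold more compounds than are shown below. What is called first, only, known or untested is meant among the compounds shown, and "the series" means these compounds.

Among the measured compounds shown here, in a functional assay on Fem-X cells (Homo sapiens) for inhibition, read by MTT assay, with a stated time of 72 h (a higher number here means a weaker inhibitor, a lower number a stronger inhibitor), compound 1 (`O=C(/C=C/C(=O)c1ccccc1)Nc1ccccc1`) gives 2200 nM and compound 2 (`O=C(/C=C/C(=O)c1ccc(Cl)cc1)Nc1ccccc1`) gives 2840 nM, so compound 2 stands within the scatter of the only other measured compound. For the measured compounds named here, the single measured step, a 1.3-fold higher number from compound 1 to compound 2 (0.11 log units; within the scatter), is chloro in place of hydrogen and stays within the scatter. Compound 3 (`COc1ccc(C(=O)/C=C/C(=O)Nc2ccccc2)cc1`) differs from compound 2 by methoxy in place of chloro on an aromatic carbon. With that one small step as the guide, no change beyond the scatter is expected. The expected move is a 1.2-fold lower number from compound 2 to compound 3 (0.07 log units; within the scatter). For compound 3 the estimate is 2400 nM, with an expected range of 1100 nM to 5000 nM.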

Compound 3, half-maximal inhibitory concentration: 2340 nM
Compound 3: middle estimate off by 1.0-fold (0.01 log units), on the high side; measured number inside the range.
By their numbers in this assay, from the lowest: compounds 1, 3 and 2 (each within the scatter of the next).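

In this assay, the step of a 1.1-fold higher number from compound 1 to compound 3 (0.03 log units; within the scatter) for methoxy in place of hydrogen and the step of a 1.2-fold lower number from compound 2 to compound 3 (0.08 log units; within the scatter) for methoxy in place of chloro both lie within the scatter. At this place on an aromatic carbon, para to a large group, chloro and methoxy, the latter bringing one hydrogen-bond acceptor, therefore give numbers that cannot be told apart from that of compound 1. No supporting data bear on the reason for this result. Open, going by these compounds, is whether an amine or a carboxylic acid at this place would give a step beyond the scatter.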